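The compounds below may be only part of what the source reports. "The series", "measured", "known", "first", "only" and "open" are said of these compounds alone.

Compound 1 `CCOC(=O)C1=C(C)NC(C)=C(C(=O)OCC)C1c1ccc(OCC(=O)Nc2nc3ccccc3s2)cc1` is the reference point of this small set. In a functional assay on the whole organism (strain Wistar) for inhibition, with Rattus norvegicus as the target, read by paw edema, with stated times of 30 min and 0.5 h, at a dose of 20 mg/kg (a lower number here means less inhibition, a higher number more inhibition at the dose given (going by the name of the read-out)), compound 1 gives 47.7%, the highest of the two numbers recorded, and its nearest neighbour is compound 2 `CCOC(=O)C1=C(C)NC(C)=C(C(=O)OCC)C1c1ccc(OCC(=O)NNC(=O)c2sccc2Cl)cc1`, which in this assay gives 10.6%. Among the measured compounds shown here, the single measured step, a number 37.1 percentage points lower from compound 1 to compound 2 (beyond the scatter), shows that exchanging the group on the amide-type nitrogen can change the read-out a great deal.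

Compound 3 `CCOC(=O)C1=C(C)NC(C)=C(C(=O)OCC)C1c1ccc(OCC(=O)NN2C(=O)c3ccccc3C2=O)cc1` is the unmeasured member. It differs from compound 1 as follows: a group of 11 heavy atoms (8 carbon, 1 nitrogen, 2 oxygen; one five-membered non-aromatic ring with 1 hetero atom, one six-membered aromatic ring of carbon only) in place of a group of 9 heavy atoms (7 carbon, 1 nitrogen, 1 sulfur; one five-membered aromatic ring with 2 hetero atoms, one six-membered aromatic ring of carbon only), on an amide-type nitrogen. The step from compound 1 to compound 2 bears on this change only loosely, since it exchanged the same group at the same place for a different nitrogen-linked group and produced a large fall. On that basis a fall is expected for compound 3 as well, though its size is uncertain, so the expected step is a number 22.7 percentage points lower from compound 1 to compound 3 (beyond the scatter). For compound 3 the estimated read-out in this assay is 25%, with a range from 8% to 45%.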

Compound 3, a percentage reported as inhibition, in the whole organism at one dose (the size of the read-out at that dose, not a potency): 34.1%
Beside the measured number, compound 3's estimate is 9.1 percentage points below it; the range from low to high includes it.
By their numbers in this assay, from the lowest: compound 2; then compound 3; then compound 1.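

In this assay, the group of 11 heavy atoms with its five-membered non-aromatic ring, taking the place of 1,3-benzothiazol-2-yl on the amide-type nitrogen, gives a number 13.6 percentage points lower from compound 1 to compound 3 (beyond the scatter), so the second replacement at this position also ends below compound 1, but by a smaller margin than the first. The two replacements are also separated from each other, with a number 23.5 percentage points higher from compound 2 to compound 3 (beyond the scatter), which shows that the read-out at this position depends on which group enters and not merely on the loss of 1,3-benzothiazol-2-yl. No measurement offered here explains why these groups differ in this way.

Going by these compounds, whether a simple amine, a carboxylic acid or a longer alkyl chain on the amide-type nitrogen would match or exceed compound 1 remains open, as three compounds give only a ranking of three groups at one position. Each compound is also represented by a reading at a single dose, so these numbers say nothing about how the ranking would hold at other doses, or whether the same groups would behave alike on a different core.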